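A few compounds are considered here, and "the series" means these few. Any claim that something is new, unique, unknown or untested is made for them only; others in the source may bear on it.

Three compounds share one core and differ only in the group on a saturated chain carbon bound to an oxygen on an aromatic ring. Compound 1 `COc1cc(CNCc2ccncc2)ccc1OCc1cnc(Cl)c(Cl)c1` carries 5,6-dichloropyridin-3-yl there, and in a functional assay on HeLa cells (Homo sapiens) for inhibition, with a stated time of 72 h (on this read-out lower numbers stand for an effect already at smaller amounts and higher numbers for an effect only at larger amounts of compound), compound 1 gives 220 nM. Compound 2 `COc1cc(CNCc2ccncc2)ccc1OCc1ccc(C)cc1` carries 4-methylphenyl, and in this assay compound 2 gives 5000 nM. Compound 3 `COc1cc(CNCc2ccncc2)ccc1OCc1ccc([N+](=O)[O-])cc1` carries 4-nitrophenyl, and in this assay compound 3 gives 440 nM, the second highest of the three numbers: it stands nearest compound 1, a 2.0-fold higher number from compound 1 to compound 3 (0.30 log units; within the scatter), and furthest from compound 2, an 11-fold lower number from compound 2 to compound 3 (1.06 log units; beyond the scatter). The remaining step, a 23-fold higher number from compound 1 to compound 2 (1.36 log units; beyond the scatter), shows how much the group at this place can matter.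

Compound 4 `COc1cc(CNCc2ccncc2)ccc1OCc1ccc(Cl)cc1Cl` has not yet been measured. 2,4-dichlorophenyl in place of 4-nitrophenyl on a saturated chain carbon bound to an oxygen on an aromatic ring Both 2,4-dichlorophenyl and the 5,6-dichloropyridin-3-yl of compound 1 bear chlorine, and compound 1 and compound 3 lie within the scatter of each other, so the two steps that touch compound 3 point the same way: no step beyond the scatter is expected for compound 4, whose number is expected to land near compound 1 and compound 3 rather than near compound 2. For compound 4 the step of a 1.8-fold lower number from compound 3 to compound 4 (0.25 log units; within the scatter) is expected. For compound 4 the expected value in this assay is 250 nM, with a range from 80 nM to 800 nM.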

Compound 4, half-maximal effective concentration: 3900 nM
Compound 4: the middle estimate sits 16-fold (1.19 log units) below what was measured; the measured number lies above the stated range.
By their numbers in this assay, from the lowest: compounds 1 and 3 (each within the scatter of the next); then compounds 4 and 2 (each within the scatter of the next).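

In this assay, bearing chlorine did not keep the number low at this place: replacing 5,6-dichloropyridin-3-yl with 2,4-dichlorophenyl gives an 18-fold higher number from compound 1 to compound 4 (1.25 log units; beyond the scatter), so two groups that both carry chlorine can lie far apart. The 2,4-dichlorophenyl group also parts from 4-nitrophenyl, with an 8.9-fold higher number from compound 3 to compound 4 (0.95 log units; beyond the scatter), while it cannot be told apart from 4-methylphenyl, with a 1.3-fold lower number from compound 2 to compound 4 (0.11 log units; within the scatter), which places compounds 2 and 4 together and apart from compounds 1 and 3. A carbon-only aromatic ring does not decide this split either, since compound 3 has one and still sits with compound 1, and nothing measured here accounts for the split.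

The compounds shown leave open which chlorine of 2,4-dichlorophenyl goes with the higher number, a question that 4-chlorophenyl and 2-chlorophenyl at this place would separate. They also leave open how much the ring nitrogen of 5,6-dichloropyridin-3-yl contributes, which a comparison with 3,4-dichlorophenyl in the same place would address.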